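The compounds below may be only part of what the source reports. "The series", "measured", "known", "first", "only" and "open" are said of these compounds alone.

Compound 1 `C/C(=C\CC/C(C)=C/CC[C@@H]1[C@@]2(C)CCC(=O)C(C)(C)[C@H]2CC[C@@]1(C)O)CC/C=C(\C)C(=O)OCc1cn(-c2ccccc2C(F)(F)F)nn1` was tested in a functional assay on A549 cells (Homo sapiens) for antiproliferative activity, read by MTT assay, with a stated time of 48 h; on this read-out lower numbers stand for stronger inhibition and higher numbers for weaker inhibition. In this assay compound 1 gives only a limit, > 150000 nM, not a number. It thus sits at the limit of > 150000 nM in this assay, at which 1 of the 3 values shown sits. For the measured compounds named here, compound 3 `C/C(=C\CC/C(C)=C/CC[C@@H]1[C@@]2(C)CCC(=O)C(C)(C)[C@H]2CC[C@@]1(C)O)CC/C=C(\C)C(=O)OCc1cn(-c2cccc(Cl)c2)nn1` gives 147000 nM in this assay, and the only step that bears here, an at least 1.0-fold lower number from compound 1 to compound 3 (0.00 log units; that floor lies within the scatter), shows that swapping one phenyl substituent for another left the result unchanged. Compound 2 `C/C(=C\CC/C(C)=C/CC[C@@H]1[C@@]2(C)CCC(=O)C(C)(C)[C@H]2CC[C@@]1(C)O)CC/C=C(\C)C(=O)OCc1cn(C[C@@H]2O[C@H](n3ccc(=O)[nH]c3=O)[C@H]3OC(C)(C)O[C@H]32)nn1`, which carries a sugar-like group instead, gives 15300 nM. Compound 4 `C/C(=C\CC/C(C)=C/CC[C@@H]1[C@@]2(C)CCC(=O)C(C)(C)[C@H]2CC[C@@]1(C)O)CC/C=C(\C)C(=O)OCc1cn(-c2ccc(Br)cc2)nn1` differs from compound 1 by 4-bromophenyl in place of 2-(trifluoromethyl)phenyl on an aromatic nitrogen. Another aryl swap is expected to move the number little, an at least 1.0-fold lower number from compound 1 to compound 4 (0.02 log units; that floor lies within the scatter). Compound 4 is therefore estimated at 140000 nM, with a range from 50000 nM to 300000 nM, and may again yield only a limit.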

Compound 4, half-maximal inhibitory concentration: > 150000 nM
Compound 4: a limit, no number (the forecaster's own chance of this, stated with the estimate: 50%); at least 1.0-fold (0.02 log units) between middle value and limit.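

In this assay compound 4 gives only a limit, so the step from compound 1, which also gives a limit, cannot be read. For the compounds shown here, the one readable step is an at least 1.0-fold higher number from compound 3 to compound 4 (0.00 log units; that floor lies within the scatter), so a third aryl group on this nitrogen brings no measurable change. This limit now recurs among the aryl compounds: the limit of > 150000 nM in this assay, at which 2 of the 4 values shown sit.

Open, from the compounds shown here alone, is whether an amine or a carboxylic acid on the phenyl ring, or a plain alkyl chain in its place, would lower the number. Also open, going by these compounds, is which part of the sugar-like group in compound 2 goes with its 15300 nM.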